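Amide phenyl groups on the shared core: toward compound 4

This account rests on a few compounds, and the source may have more. Where it says the series, first, only, none or still open, it means among the compounds named here.

All three measured compounds share one core and differ in the phenyl group on the amide carbonyl. In a functional assay on MCF7 cells (Homo sapiens) for inhibition, read by MTT assay (on this read-out higher numbers stand for weaker inhibition of growth and lower numbers for stronger inhibition of growth), compound 1 `COc1cc2oc(-c3cccc(NC(=O)c4ccc(C#N)cc4)c3)cc(=O)c2c(OC)c1OC` gives 12700 nM, compound 2 `COc1cc2oc(-c3cccc(NC(=O)c4cccc(C#N)c4)c3)cc(=O)c2c(OC)c1OC` gives 41700 nM and compound 3 `COC(=O)c1ccc(C(=O)Nc2cccc(-c3cc(=O)c4c(OC)c(OC)c(OC)cc4o3)c2)cc1` gives 30300 nM. Compound 3 has the second highest of the three numbers, though that rank means little on one side: a 1.4-fold lower number from compound 2 to compound 3 (0.14 log units; within the scatter), so those two are not separated. On the other side, a 2.4-fold higher number from compound 1 to compound 3 (0.38 log units; beyond the scatter), a modest gap.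

Compound 4 `COc1cccc(C(=O)Nc2cccc(-c3cc(=O)c4c(OC)c(OC)c(OC)cc4o3)c2)c1` carries 3-methoxyphenyl in place of 4-(methoxycarbonyl)phenyl on a carbonyl carbon. Among the measured compounds shown here, no measured step makes this exact change, so the evidence is indirect. The closest parallel is the replacement of one phenyl group by a 3-substituted one, seen in a 1.4-fold lower number from compound 2 to compound 3 (0.14 log units; within the scatter) read in reverse, which stays within the scatter. The shift of the cyano group gives a 3.3-fold higher number from compound 1 to compound 2 (0.52 log units; beyond the scatter), the largest step in the set and still modest. With steps this small, no step beyond the scatter is expected in this assay. The expected step is a 1.0-fold lower number from compound 3 to compound 4 (0.00 log units; within the scatter). For compound 4 the estimated value is 30000 nM, with an expected range of 12000 nM to 75000 nM.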

Compound 4, concentration for 50% growth inhibition: 7670 nM
Compound 4: the middle estimate sits 3.9-fold (0.59 log units) above what was measured, outside the stated range (below it).
By their numbers in this assay, from the lowest: compounds 4 and 1 (each within the scatter of the next); then compounds 3 and 2 (each within the scatter of the next).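

Notes on the position: in this assay, compound 4 gives 7670 nM, and the change to 3-methoxyphenyl on the carbonyl carbon yields a 4.0-fold lower number from compound 3 to compound 4 (0.60 log units; beyond the scatter), a move beyond the scatter on a swap of phenyl groups where the earlier pair of compound 2 and compound 3 stayed within it. The comparison with the same substitution place is sharper still, with methoxy in place of cyano giving a 5.4-fold lower number from compound 2 to compound 4 (0.74 log units; beyond the scatter), so the group on the 3-substituted phenyl changes the read-out and a 3-substituted phenyl does not by itself go with the higher numbers, as compound 2 alone had left possible. Compound 4 also reaches the level of the 4-cyanophenyl amide, with a 1.7-fold lower number from compound 1 to compound 4 (0.22 log units; within the scatter) leaving the two unseparated, while compound 3 shows that a 4-substituted phenyl does not guarantee that level either; the data offer no explanation for any of these shifts.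

Open, from the compounds shown here alone, is whether methoxy keeps this level as 4-methoxyphenyl, which would separate the group from its place on the ring. Also open, going by these compounds, is how an amine, a hydroxyl or a longer chain such as ethoxy would read in place of that methoxy.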